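This account rests on a few compounds, and the source may have more. Where it says the series, first, only, none or still open, it means among the compounds named here.

In an assay for inhibition of HSP60/HSP10 (Homo sapiens), with a stated time of 60 min (on this read-out higher numbers stand for weaker inhibition and lower numbers for stronger inhibition), three compounds have been measured so far. Compound 1 `COc1c(Br)cc(Br)cc1C(=O)Nc1ccccc1` gives > 100000 nM, a limit of the assay rather than a number. Compound 2 `COc1c(Br)cc(Br)cc1C(=O)Nc1ccc(Sc2nc3ccccc3s2)cc1` gives > 100000 nM, again a limit. For the measured compounds named here, compound 3 `O=C(Nc1cccc(Cl)c1)c1cc(Br)cc(Br)c1O` gives 29000 nM in this assay, and this is the only real number among the three; the other two values sit at the limit of > 100000 nM in this assay, at which 2 of the 3 values shown sit. Going by the values given here, compound 3 therefore stands alone as the one compound with a measured value, and it is also the one compound carrying a hydroxy, while compounds 1 and 2 carry a methoxy.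

Compound 4 `COc1c(Br)cc(Br)cc1C(=O)Nc1cccc(Cl)c1` has not yet been measured. It differs from compound 3 in a single place: methyl in place of hydrogen on an oxygen on an aromatic ring. This change gives compound 4 the methoxy that compounds 1 and 2 already share.

Since the methoxy compounds 1 and 2 both sit at the limit, the step from compound 3 to compound 4 is expected to weaken inhibition, by about a 3.4-fold higher number from compound 3 to compound 4 (0.54 log units; beyond the scatter), a step beyond the usual scatter. Compound 4 is estimated at 100000 nM in this assay, with a likely range from 40000 nM to 300000 nM, and a fair chance that only a limit is reported.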

Compound 4, half-maximal inhibitory concentration: > 100000 nM
Compound 4 gave a limit, no number; the forecaster's own chance of this, stated with the estimate: 65%; the middle value lies on the limit itself.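

Until now, the hydroxy of compound 3 and the methoxy of compounds 1 and 2 came with differences elsewhere in the molecule, so the two groups could not be compared directly. For the compounds shown here, compound 4 allows that comparison: methyl in place of hydrogen on this oxygen gives an at least 3.4-fold higher number from compound 3 to compound 4 (0.53 log units; beyond the scatter), so in this pair the hydroxy form is the one with a measurable value. The step between compound 1 and compound 4 cannot be read, as both values are limits, and most of the series now sits at the same limit: the limit of > 100000 nM in this assay, at which 3 of the 4 values shown sit.

As far as these compounds go, it remains open whether another group on this aromatic carbon, such as an amine or a carboxylic acid, would also give a measurable value. From the compounds shown here alone, the effect of replacing the chloro of compound 3 with a fluoro or a nitrile also remains open.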